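Dropping the chloro from the 4-chlorophenyl of compound 1

The compounds below may be only part of what the source reports. "The series", "measured", "known", "first", "only" and "open" are said of these compounds alone.

Compound 1 `COc1cc(N)c(Cl)cc1NC(=O)C1CCN(Cc2ccc(Cl)cc2)CC1` is the only one of the three measured compounds with a number: in a functional assay on the whole organism for antagonist activity, with Mus musculus as the target (on this read-out higher numbers stand for an effect only at larger amounts of compound and lower numbers for an effect already at smaller amounts), compound 1 gives 1.2 mg/kg. Compound 2 `CCCCN1CCC(C(=O)Nc2cc(Cl)c(N)cc2OC)CC1` shows only a limit in this assay, > 10 mg/kg. Compound 3 `COc1cc(N)c(Cl)cc1NC(=O)C1CCN(Cc2ccccc2Cl)CC1` likewise shows only a limit, > 4 mg/kg. Both measured steps raised the number: an at least 8.3-fold higher number from compound 1 to compound 2 (0.92 log units; beyond the scatter) and an at least 3.3-fold higher number from compound 1 to compound 3 (0.52 log units; beyond the scatter). Compound 4 `COc1cc(N)c(Cl)cc1NC(=O)C1CCN(Cc2ccccc2)CC1` differs from compound 1 in one place: hydrogen in place of chloro on an aromatic carbon, so the 4-chlorophenyl becomes phenyl. For the measured compounds named here, no measured step removes this chloro alone, yet both changes to the 4-chlorophenyl pushed the number up, so in this assay a modest rise is expected, a 2.5-fold higher number from compound 1 to compound 4 (0.40 log units; beyond the scatter). Compound 4 is estimated at 3 mg/kg, within 1 mg/kg to 9 mg/kg.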

Compound 4, dose for half-maximal effect: 0.5 mg/kg
For compound 4 the middle estimate is 6.0-fold (0.78 log units) above the measured one, outside the stated range (below it).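

In this assay the chloro of the 4-chlorophenyl turns out not to be needed, with a 2.4-fold lower number from compound 1 to compound 4 (0.38 log units; beyond the scatter). The plain phenyl also compares well with the 2-chlorophenyl, with an at least 8.0-fold lower number from compound 3 to compound 4 (0.90 log units; beyond the scatter), and with the propyl, with an at least 20-fold lower number from compound 2 to compound 4 (1.30 log units; beyond the scatter), which leaves compound 4 with the lowest number of the four. Compound 2 and compound 3 each give only a limit, so those last two steps are minimum sizes.

Going by these compounds, whether fluoro or methoxy in place of this chloro would lower the number further stays open. So does the effect of a longer chain carrying the phenyl.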